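The source may report more compounds than this note shows. Statements on the series, on what has been measured and on what is new or still open speak of the compounds shown alone.

Measured in a functional assay on OVCAR-8 cells (Homo sapiens) for inhibition, read by sulforhodamine B assay, with a stated time of 48 h; on this read-out higher numbers stand for weaker inhibition of growth and lower numbers for stronger inhibition of growth:
- compound 1 `O=C(Cc1csc2nc(-c3ccc(Br)cc3)cn12)N/N=C/c1ccccc1`: 2340 nM
- compound 2 `O=C(Cc1csc2nc(-c3ccc(Br)cc3)cn12)N/N=C/c1ccccc1O`: 2290 nM
- compound 3 `O=C(Cc1csc2nc(-c3ccc(Br)cc3)cn12)N/N=C/c1ccc(O)cc1`: 7080 nM

Of these three, compound 3 has the highest number, 7080 nM, which makes it the weakest growth inhibitor of the set. The next analogue, compound 4 `COc1cccc(OC)c1/C=N/NC(=O)Cc1csc2nc(-c3ccc(Br)cc3)cn12`, has 2,6-dimethoxyphenyl in place of 4-hydroxyphenyl on a carbon with a double bond to nitrogen.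

Among the compounds with values here, no measured compound carries a methoxy group, so the evidence is indirect. Putting hydroxy in place of hydrogen on an aromatic carbon gave a 1.0-fold lower number from compound 1 to compound 2 (0.01 log units; within the scatter) in one case and a 3.0-fold higher number from compound 1 to compound 3 (0.48 log units; beyond the scatter) in another. Exchanging one hydroxyphenyl group for the other gave a 3.1-fold higher number from compound 2 to compound 3 (0.49 log units; beyond the scatter). Compound 4 gives up the 4-hydroxyphenyl group that went with the higher number in a 3.0-fold higher number from compound 1 to compound 3 (0.48 log units; beyond the scatter), so a small move towards lower numbers in this assay seems likely, though perhaps none beyond the scatter. The expected change is a 1.9-fold lower number from compound 3 to compound 4 (0.27 log units; within the scatter). The estimated value for compound 4 is 3800 nM, with an expected range from 1300 nM to 10000 nM.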

Compound 4, concentration for 50% growth inhibition: 11500 nM
The estimate for compound 4 lay 3.0-fold (0.48 log units) below the measured number; the measured number lies above the stated range.
By their numbers in this assay, from the lowest: compounds 2 and 1 (each within the scatter of the next); then compounds 3 and 4 (each within the scatter of the next).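

Replacing 4-hydroxyphenyl with 2,6-dimethoxyphenyl gives a 1.6-fold higher number from compound 3 to compound 4 (0.21 log units; within the scatter), so this assay does not separate these two groups at this position. The picture differs against the other two groups: replacing 2-hydroxyphenyl gives a 5.0-fold higher number from compound 2 to compound 4 (0.70 log units; beyond the scatter), and replacing phenyl gives a 4.9-fold higher number from compound 1 to compound 4 (0.69 log units; beyond the scatter), so the four compounds fall into two sets, with 2,6-dimethoxyphenyl on the side of weaker growth inhibition alongside 4-hydroxyphenyl. No measurement here explains this split.

Within the data shown here, it remains open whether a phenyl ring carrying a single methoxy group would fall with the stronger or the weaker set, since the only methoxy groups here come as a pair on one ring. From the compounds shown here alone, how an amine or a carboxylic acid on that ring would change growth inhibition also remains unknown.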